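A few compounds are considered here, and "the series" means these few. Any claim that something is new, unique, unknown or untested is made for them only; others in the source may bear on it.

Compound 2 `COc1cc(-c2nn(-c3cccc(NC(=O)c4ccc(Cl)c(C(F)(F)F)c4)c3)cc2-c2ccncc2)ccc1Cl` stands in a functional assay on ACHN cells (Homo sapiens) for inhibition, read by sulforhodamine B assay, with a stated time of 48 h (on this read-out higher numbers stand for lower toxicity in this test and lower numbers for higher toxicity in this test), only at a limit of the assay, giving > 32500 nM. Compound 1 `COc1cc(-c2nn(-c3cccc(NC(=O)c4cccc(C(F)(F)F)c4)c3)cc2-c2ccncc2)ccc1Cl` likewise sits at a limit in this assay, giving > 50000 nM. Going by the values given here, the step that the two limits leave unreadable from compound 1 to compound 2 is therefore not readable, and it is the only measured step available. Compound 3 `COc1cc(-c2nn(-c3cccc(NC(=O)c4ccccc4)c3)cc2-c2ccncc2)ccc1Cl` differs from compound 2 by phenyl in place of 4-chloro-3-(trifluoromethyl)phenyl on a carbonyl carbon. Among the compounds with values here, no measured step bears on this change, so no shift beyond the scatter is expected, and compound 3 is estimated at 60000 nM in this assay, between 20000 nM and 200000 nM. The expected step that the limit leaves unreadable from compound 2 to compound 3 is thus essentially flat.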

Compound 3, concentration lethal to 50% of the cells: > 100000 nM
Compound 3 was reported as a limit; the forecaster's own chance of this, stated with the estimate: 85%; middle value at least 1.6-fold (0.22 log units) away from the limit.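

Compound 3, like compound 1 and compound 2, sits at a limit in this assay, so no step among these three compounds can be read. As far as these compounds go, how their toxicity in this assay actually compares remains open.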